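The source may hold more compounds than are shown below. What is called first, only, known or untested is meant among the compounds shown, and "the series" means these compounds.

In an assay on isolated protein for inhibition of sulfide:quinone oxidoreductase, mitochondrial (Homo sapiens) (a lower number here means a stronger inhibitor, a higher number a weaker inhibitor), the measured compounds stand as follows:
compound 1 `COc1nc(-c2ccccc2)cc(-c2ccc(F)cc2)c1C#N` gives 25 nM
compound 2 `COc1ccc(-c2cc(-c3ccc(F)cc3)c(C#N)c(OC)n2)cc1` gives 1360 nM
compound 3 `COc1ccccc1-c1cc(-c2ccc(F)cc2)c(C#N)c(OC)n1` gives 75 nM

Compound 3 stands second of the three, set apart from compound 1 by a 3.0-fold higher number from compound 1 to compound 3 (0.48 log units; beyond the scatter) and from compound 2 by an 18-fold lower number from compound 2 to compound 3 (1.26 log units; beyond the scatter). Compound 4 `COc1nc(-c2cccnc2)cc(-c2ccc(F)cc2)c1C#N` differs from compound 3 in one place: pyridin-3-yl in place of 2-methoxyphenyl on an aromatic carbon. Two measured steps alter the same ring and so bear on this change: an 18-fold lower number from compound 2 to compound 3 (1.26 log units; beyond the scatter) shows a large shift when the methoxy changes position within that ring, while a 3.0-fold higher number from compound 1 to compound 3 (0.48 log units; beyond the scatter) shows the modest cost of adding it at all. Compound 4 carries a ring without methoxy, resembling compound 1 more than compound 3, so a modest improvement is expected, a 1.9-fold lower number from compound 3 to compound 4 (0.27 log units; within the scatter). Compound 4 is estimated at 40 nM, within a range from 10 nM to 160 nM.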

Compound 4, half-maximal inhibitory concentration: 213 nM
Beside the measured number, compound 4's estimate is 5.3-fold (0.73 log units) below it; measured number above the stated range.
By their numbers in this assay, from the lowest: compound 1; then compound 3; then compound 4; then compound 2.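

Dropping the methoxy does not by itself lower the number: with pyridin-3-yl in this place there is a 2.8-fold higher number from compound 3 to compound 4 (0.45 log units; beyond the scatter), and against plain phenyl there is an 8.5-fold higher number from compound 1 to compound 4 (0.93 log units; beyond the scatter), so a single ring nitrogen costs more here than the 2-methoxyphenyl group does. The same ring still does better than 4-methoxyphenyl, with a 6.4-fold lower number from compound 2 to compound 4 (0.81 log units; beyond the scatter), and plain phenyl in compound 1 remains the strongest of the four. Nothing shown explains why the ring nitrogen raises the number. Open, on these data alone, is how pyridin-4-yl, with its nitrogen elsewhere in the ring, would compare, or a phenyl ring carrying an amine.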